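The compounds below may be only part of what the source reports. "The series", "measured", "known", "first", "only" and "open" are said of these compounds alone.

Measured compounds in an ADME assay on 2209-23 cells (Homo sapiens) for cytotoxicity, read by WST assay; a lower number here means that less compound is tolerated, a higher number that more compound is tolerated:
Compound 1 `N#Cc1ccc2c(c1)S(=O)(=O)C=C(c1c(O)c3cc(F)ccc3n(Cc3ccc(F)cc3)c1=O)N2` gives > 50000 nM, a limit of the assay.
Compound 2 `CC(=O)Nc1ccc2c(c1)S(=O)(=O)C=C(c1c(O)c3cc(F)ccc3n(Cc3ccc(F)cc3)c1=O)N2` gives > 50000 nM, also a limit of the assay.
Compound 3 `CS(=O)(=O)Nc1ccc2c(c1)S(=O)(=O)C=C(c1c(O)c3cc(F)ccc3n(Cc3ccccc3)c1=O)N2` gives > 50000 nM, again a limit of the assay.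

In this assay compound 3 therefore stands only at a limit, and the same holds for the two further measured values; all three sit at the limit of > 50000 nM in this assay, at which 3 of the 3 values shown sit. No number separates compound 3 from compound 1 or from compound 2.

The step to compound 4 `CS(=O)(=O)Nc1ccc2c(c1)S(=O)(=O)C=C(c1c(O)c3cc(F)ccc3n(Cc3ccncc3)c1=O)N2` is pyridin-4-yl in place of phenyl on a saturated chain carbon bound to an aromatic nitrogen. Among the compounds with values here, the only step between measured compounds that differ in one place, a step that the two limits leave unreadable from compound 1 to compound 2, concerns a different part of the core and is left unreadable by its two limits, so it supplies no size. Within the data shown here, no measured step bears directly on the exchange of the phenyl for pyridin-4-yl on the saturated chain carbon bound to the aromatic nitrogen. With every measured value sitting at the limit of > 50000 nM in this assay, at which 3 of the 3 values shown sit, the expectation for this assay is no step beyond the scatter and, most likely, a further limit rather than a number. Compound 4 is expected at 60000 nM, with a range from 25000 nM to 200000 nM. The step from compound 3 to compound 4 is accordingly estimated as a step that the limit leaves unreadable from compound 3 to compound 4.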

Compound 4, half-maximal cytotoxic concentration: > 50000 nM
Compound 4 was reported as a limit; the forecaster's own chance of this, stated with the estimate: 85%; the middle value lies beyond the limit too.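

In this assay compound 4 gives > 50000 nM, a limit of the assay. Compound 3 gives > 50000 nM, also a limit, so the exchange of phenyl for pyridin-4-yl cannot be read as a step. The compounds shown leave open at what concentration any member of the series would give a number rather than a limit: the limit of > 50000 nM in this assay, at which 4 of the 4 values shown sit.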